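The source may hold more compounds than are shown below. What is called first, only, known or untested is meant among the compounds shown, and "the series" means these compounds.

Measured in a functional assay on B16 cells (Mus musculus) for inhibition; on this read-out lower numbers stand for stronger inhibition and higher numbers for weaker inhibition:
- Compound 1 `C/C=C/C(=O)OCc1cc(=O)oc2cc(OC)c(OC)cc12`: > 10 ug/mL, which is a limit and not a number
- Compound 2 `COc1ccc(/C=C/C(=O)OCc2cc(=O)oc3cc(OC)c(OC)cc23)cc1`: 0.96 ug/mL

Among the compounds with values here, compound 2, at 0.96 ug/mL, holds the only true number in this assay. Compound 3 `COc1cc2oc(=O)cc(COC(=O)/C=C/c3ccc(Cl)cc3)c2cc1OC` carries chloro in place of methoxy on an aromatic carbon, para to a large group (chloro in place of methoxy on an aromatic carbon). Within the data shown here, only one measured step bears on this, the large at least 10-fold lower number from compound 1 to compound 2 (1.01 log units; beyond the scatter), where 4-methoxyphenyl replaced methyl. That step does not test a change on the aromatic ring, and 4-chlorophenyl keeps the ring, so no change beyond the scatter is expected. The expected change is a 1.0-fold higher number from compound 2 to compound 3 (0.02 log units; within the scatter). The estimate for compound 3 is 1 ug/mL, within a range of 0.3 ug/mL to 4 ug/mL.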

Compound 3, half-maximal inhibitory concentration: > 10 ug/mL
Compound 3: no number, only a limit; the forecaster's own chance of this, stated with the estimate: 10%; middle value at least 10-fold (1.00 log units) away from the limit.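

In this assay, the group on the aromatic carbon para to a large group matters, not just the presence of the ring: swapping methoxy for chloro gives an at least 10-fold higher number from compound 2 to compound 3 (1.01 log units; beyond the scatter). Compound 3 gives > 10 ug/mL, which is a limit and not a number. The comparison between compound 1 and compound 3 cannot be read, as both values are limits: the limit of > 10 ug/mL in this assay, at which 2 of the 3 values shown sit.

From the compounds shown here alone, it remains open whether methoxy alone can hold the number of compound 2 at this place, or whether hydroxy or an amine could do the same.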